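Compound 2 to Compound 4: Expected Oral Plasma Exposure

The source may report more compounds than this note shows. Statements on the series, on what has been measured and on what is new or still open speak of the compounds shown alone.

Compound 1, `O=C(Nc1ccc(F)c(-c2nc3ncc(-c4cccc(F)c4)cc3[nH]2)c1)N1CCCC1`, gives 7000 nM in an ADME assay on the whole organism (Mus musculus, strain Swiss Webster) for pharmacokinetics, read by LC-MS, at a dose of 50 mg/kg by the oral route; on this read-out lower numbers stand for lower exposure and higher numbers for higher exposure at the dose given.
Compound 2, `O=C(Nc1ccc(F)c(-c2nc3ncc(-c4ccccc4F)cc3[nH]2)c1)N1CCCC1`, gives 2230 nM in this assay.
Compound 3, `O=C(Nc1ccc(F)c(-c2nc3ncc(-c4cc(F)ccc4F)cc3[nH]2)c1)N1CCCC1`, gives 2800 nM in this assay.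

Among these three, compound 2 has the lowest number in this assay, but compound 3 lies within the scatter of it (a 1.3-fold higher number from compound 2 to compound 3 (0.10 log units; within the scatter)), and only compound 1 stands clearly apart (a 3.1-fold lower number from compound 1 to compound 2 (0.50 log units; beyond the scatter)). Compound 4, `O=C(Nc1ccc(F)c(-c2nc3ncc(-c4cncc(F)c4)cc3[nH]2)c1)N1CCCC1`, differs from compound 2 in one place: 5-fluoropyridin-3-yl in place of 2-fluorophenyl on an aromatic carbon. Within the data shown here, no measured step exchanges a ring carbon for a ring nitrogen, so the measured steps give no direct guide; they show only that moving or adding a fluorine shifts the number modestly at most. A step no larger than that, in either direction, is therefore expected: a 1.1-fold higher number from compound 2 to compound 4 (0.05 log units; within the scatter). Compound 4 is estimated at 2500 nM, with a range from 900 nM to 7000 nM.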

Compound 4, maximal plasma concentration: 1070 nM
Compound 4: middle estimate off by 2.3-fold (0.37 log units), on the high side, within the range that was stated.
By their numbers in this assay, from the lowest: compound 4; then compounds 2 and 3 (each within the scatter of the next); then compound 1.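

In this assay, 5-fluoropyridin-3-yl on this aromatic carbon gives a lower number than each of the three fluorophenyl groups (a 2.1-fold lower number from compound 2 to compound 4 (0.32 log units; beyond the scatter); a 2.6-fold lower number from compound 3 to compound 4 (0.42 log units; beyond the scatter); a 6.5-fold lower number from compound 1 to compound 4 (0.82 log units; beyond the scatter)). Among these compounds, the earlier compounds varied only fluorine on a carbon-only ring, so this is the first sign that a ring nitrogen at this position also moves the number beyond the scatter. Nothing available explains the drop. Still open, from the compounds shown here alone, is how a pyridin-3-yl without fluorine would compare, or a pyridine ring carrying an amine or a methoxy group.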